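From 4-fluorophenyl to cyclohexyl, starting at an assay limit

A few compounds are considered here, and "the series" means these few. Any claim that something is new, unique, unknown or untested is made for them only; others in the source may bear on it.

Measured in a functional assay on MCF7 cells (Homo sapiens) for antiproliferative activity, read by MTT assay, with a stated time of 72 h; on this read-out higher numbers stand for weaker inhibition and lower numbers for stronger inhibition:
- Compound 1 `COc1cccc(N2C(=O)COc3ccc(-c4cnc(OC)c(NS(=O)(=O)c5ccc(F)cc5)c4)cc32)c1`: > 40000 nM (a limit)
- Compound 2 `COc1ncc(-c2ccc3c(c2)N(c2ccc(F)cc2)C(=O)CO3)cc1NS(=O)(=O)c1ccc(F)cc1`: > 40000 nM (a limit)

Compound 2 has no numerical potency in this assay. Its entry of > 40000 nM is a limit of the assay. Compound 1 offers no number for comparison either, and its entry of > 40000 nM is also a limit. The measurements therefore amount to the limit of > 40000 nM in this assay, at which 2 of the 2 values shown sit.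

Compound 3 `COc1ncc(-c2ccc3c(c2)N(C2CCCCC2)C(=O)CO3)cc1NS(=O)(=O)c1ccc(F)cc1` differs from compound 2 by cyclohexyl in place of 4-fluorophenyl on an amide-type nitrogen in a ring. For the measured compounds named here, the only measured step at this nitrogen is a step that the two limits leave unreadable from compound 1 to compound 2, so it gives no size to scale from. Going by the values given here, it shows only that neither group tested there brought a reading inside the range of this assay. No step beyond the scatter is therefore expected, and compound 3 will most likely be reported as a limit as well. The expected change is a number no higher from compound 2 to compound 3 (the limit leaves the size open). For compound 3 the estimated value is 40000 nM, with an expected range from 12000 nM to 80000 nM.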

Compound 3, half-maximal inhibitory concentration: 30100 nM
Compound 3: middle estimate off by 1.3-fold (0.12 log units), on the high side; low and high end bracket the measured number.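

At the amide-type nitrogen, cyclohexyl is the first group shown to bring a reading inside the range of this assay, where compound 3 gives 30100 nM. Against the 4-fluorophenyl group the change gives an at least 1.3-fold lower number from compound 2 to compound 3 (0.12 log units; that floor lies within the scatter), and against the 3-methoxyphenyl group it gives an at least 1.3-fold lower number from compound 1 to compound 3 (0.12 log units; that floor lies within the scatter); both are floors, and the full size of either step stays open. Compound 3 therefore stands apart from the two compounds with an aromatic ring at this nitrogen only in having a number, and the set as a whole stays tied to the edge of the assay's range: the limit of > 40000 nM in this assay, at which 2 of the 3 values shown sit.

A single compound with a non-aromatic ring cannot show whether that ring, or some other difference between these groups, accounts for the reading, nor whether any group at this nitrogen can bring a reading far from the limit. From the compounds shown here alone, what methyl, an n-butyl chain or a piperidine ring would give at this nitrogen remains open, as does the effect of changes elsewhere on the shared core.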